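Removing the 2-methylbenzyl group from compound 3

This account rests on a few compounds, and the source may have more. Where it says the series, first, only, none or still open, it means among the compounds named here.

Three compounds have been measured in a functional assay on DU-145 cells (Homo sapiens) for inhibition, read by WST assay, with a stated time of 48 h (a lower number here means a stronger inhibitor of growth, a higher number a weaker inhibitor of growth), and a fourth awaits measurement

Compound 1 (`C=C(C)C(=O)N(Cc1cccc(Br)c1)C(=O)/C=C/c1cc(OC)c(OC)c(OC)c1`) gives 5700 nM
Compound 2 (`C=C(C)C(=O)N(C)C(=O)/C=C/c1cc(OC)c(OC)c(OC)c1`) gives 5600 nM
Compound 3 (`C=C(C)C(=O)N(Cc1ccccc1C)C(=O)/C=C/c1cc(OC)c(OC)c(OC)c1`) gives 4200 nM

Compound 3 stands within the scatter of the other two, with a 1.3-fold lower number from compound 2 to compound 3 (0.12 log units; within the scatter) and a 1.4-fold lower number from compound 1 to compound 3 (0.13 log units; within the scatter) as the steps that reach it. Compound 4 (`C=C(C)C(=O)NC(=O)/C=C/c1cc(OC)c(OC)c(OC)c1`) differs from it by hydrogen in place of 2-methylbenzyl on an amide-type nitrogen. Going by the values given here, no measured compound carries hydrogen on that nitrogen, so the evidence is indirect. Still, the group on that nitrogen differs across all three measured compounds, and the third step, a 1.0-fold lower number from compound 1 to compound 2 (0.01 log units; within the scatter), is as small as the other two. On this basis, no step beyond the scatter is expected in this assay. The expected step is small (a 1.1-fold higher number from compound 3 to compound 4 (0.06 log units; within the scatter)). Compound 4 is estimated at 4800 nM (expected range 2000 nM to 11000 nM).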

Compound 4, concentration for 50% growth inhibition: 8600 nM
Compound 4: middle estimate off by 1.8-fold (0.25 log units), on the low side; the measured number falls inside the stated range.
By their numbers in this assay, from the lowest: compounds 3, 2, 1 and 4 (each within the scatter of the next, the first and the last beyond it).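

Going by these compounds alone, with the amide hydrogen on this nitrogen, this assay gives the first step at this position to pass the scatter (a 2.0-fold higher number from compound 3 to compound 4 (0.31 log units; beyond the scatter)), although it is modest. The same replacement stays within the scatter when it starts from the methyl group (a 1.5-fold higher number from compound 2 to compound 4 (0.19 log units; within the scatter)) and from the 3-bromobenzyl group (a 1.5-fold higher number from compound 1 to compound 4 (0.18 log units; within the scatter)), so the hydrogen separates compound 4 only from compound 3 and does not set it apart from all the substituted compounds. Nothing available accounts for this step.

The compounds shown leave open whether an ethyl group, a longer chain or a plain benzyl on this nitrogen would stand nearer compound 3 or compound 4. They also leave open whether a benzyl group carrying an amine or a carboxylic acid would give a step well beyond the scatter.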